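The source may report more compounds than this note shows. Statements on the series, on what has been measured and on what is new or still open speak of the compounds shown alone.

Compounds measured so far:
- compound 1 `CC1(C)S[C@@H]2/C(=C\C(=O)c3ccc4ccccc4c3)C(=O)N2[C@H]1C(=O)OC(c1ccccc1)c1ccccc1`: 36500 nM
- compound 2 `CC(=O)/C=C1\C[C@H]2SC(C)(C)[C@H](C(=O)OC(c3ccccc3)c3ccccc3)N2C1=O`: > 100000 nM (a limit of the assay, not a number)
- compound 3 `CC1(C)[C@H](C(=O)OC(c2ccccc2)c2ccccc2)N2C(=O)/C(=C/C(=O)c3ccc([N+](=O)[O-])cc3)[C@H]2[S+]1[O-]`: 48200 nM

Of the compounds shown here, three have been tested in a functional assay on A-375 cells (Homo sapiens) for cytotoxicity, read by MTT assay, with a stated time of 48 h; a higher number here means a weaker inhibitor, a lower number a stronger inhibitor. Compound 1 gives 36500 nM, the lower of the two numbers recorded. Compound 3 gives 48200 nM in this assay, which lies within the usual scatter of the value for compound 1, so the two cannot be told apart. Compound 2 in this assay reaches only a limit of the assay, namely > 100000 nM, which is the limit of > 100000 nM in this assay, at which 1 of the 3 values shown sits.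

Compound 4 `CCOC(=O)/C=C1/C(=O)N2[C@@H]1SC(C)(C)[C@@H]2C(=O)OC(c1ccccc1)c1ccccc1` is the next member to be assessed. It differs from compound 1 in one place: ethoxy in place of naphthalen-2-yl on a carbonyl carbon. Among the measured compounds shown here, no step between two measured compounds follows this change, so its size cannot be read from the data. Compound 2 carries a small methyl ketone where compound 1 has the larger naphthalenyl ketone and returns only a limit, and compound 4 likewise trades the naphthalenyl for a small ethoxy group.

On that basis compound 4 is expected to be a weaker inhibitor than compound 1, the step from compound 1 to compound 4 estimated at a 2.7-fold higher number from compound 1 to compound 4 (0.44 log units; beyond the scatter). Compound 4 is therefore estimated at 100000 nM, with a range from 40000 nM to 300000 nM, and a real chance that only a limit is returned.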

Compound 4, half-maximal inhibitory concentration: 7000 nM
Beside the measured number, compound 4's estimate is 14-fold (1.15 log units) above it; the whole stated range lies above it.
By their numbers in this assay, from the lowest: compound 4; then compounds 1 and 3 (each within the scatter of the next). At a limit, above all of these: compound 2.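

In this assay the series now has its first step between compounds that differ in one place, and it reads a 5.2-fold lower number from compound 1 to compound 4 (0.72 log units; beyond the scatter) as naphthalen-2-yl gives way to ethoxy at a carbonyl carbon whose other neighbour is the double-bonded chain carbon. This place therefore does not depend on the two six-membered aromatic rings of naphthalen-2-yl for a measurable effect on these cells, since the smaller ethoxy group, with no ring, goes with the lower number. The change swaps ring, size and a hydrogen-bond acceptor all at once, and nothing shown here says which of these accounts for the step.

On these data alone, whether the trend carries on at this carbonyl carbon with a methoxy group, a longer chain such as butoxy, a carboxylic acid or an amine stays open. So does the question of whether a single phenyl ring would behave like naphthalen-2-yl or like ethoxy, and whether the same exchange gives a step of similar size on other parts of the series.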